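Fluoro for Hydrogen: Estimating Compound 4

The source may hold more compounds than are shown below. What is called first, only, known or untested is meant among the compounds shown, and "the series" means these compounds.

Measured compounds:
Compound 1 `N/C(=N\NC(=S)N1CCCCCC1)c1ccccn1` gives 3000 nM in a functional assay on A-431 cells (Homo sapiens) for cytotoxicity, read by MTT assay, with a stated time of 72 h; on this read-out higher numbers stand for weaker inhibition and lower numbers for stronger inhibition.
Compound 2 `N/C(=N\NC(=S)N1CCOCC1)c1ccccn1` gives 4800 nM in this assay.
Compound 3 `N/C(=N\NC(=S)N1CCOCC1)c1ccc(F)cn1` gives 4000 nM in this assay.

Compound 2 and compound 3 differ by fluoro in place of hydrogen on an aromatic carbon, and this change produced the step of a 1.2-fold lower number from compound 2 to compound 3 (0.08 log units; within the scatter). The cores of compound 1 and compound 2 differ, but that difference is not broken down here. Compound 4 `N/C(=N\NC(=S)N1CCCCCC1)c1ccc(F)cn1` has not yet been measured; it differs from compound 1 by fluoro in place of hydrogen on an aromatic carbon, the same change as between compound 2 and compound 3.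

Since the earlier step stayed within the scatter, compound 4 is expected to give a number close to that of compound 1, with an estimated step of a 1.2-fold lower number from compound 1 to compound 4 (0.06 log units; within the scatter). The estimate for compound 4 in this assay is 2600 nM, expected to fall between 1200 nM and 6000 nM.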

Compound 4, half-maximal inhibitory concentration: 1000 nM
For compound 4 the middle estimate is 2.6-fold (0.41 log units) above the measured one, and the stated range ends above it.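

In this assay, fluoro in place of hydrogen on an aromatic carbon gave a 3.0-fold lower number from compound 1 to compound 4 (0.48 log units; beyond the scatter). Set beside the earlier result, this step gives no ground for saying that the change behaves differently on the two cores: the same change on two cores in this assay, a 1.2-fold lower number (0.08 log units; within the scatter) from compound 2 to compound 3 and a 3.0-fold lower number (0.48 log units; beyond the scatter) from compound 1 to compound 4, 2.5-fold (0.40 log units) apart, within the scatter of two such steps. Nor does it show that the change carries over with a fixed size, as only two cores are compared and only the step on the core of compound 1 lies beyond the scatter.

The compounds shown leave open whether chloro or methoxy on the same aromatic carbon would give a similar step. They also leave open whether the fluoro step would hold with a piperidine or a dimethylamino group in place of the rings in compound 1 and compound 2.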